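Swapping 4-Butoxyphenyl for 3-Chlorophenyl

The source may report more compounds than this note shows. Statements on the series, on what has been measured and on what is new or still open speak of the compounds shown alone.

In a functional assay on A549 cells (Homo sapiens) for antiproliferative activity, read by MTT assay, with a stated time of 24 h (on this read-out lower numbers stand for stronger inhibition and higher numbers for weaker inhibition), compound 1 (`O=C(NNc1ccccc1F)c1ccc(NS(=O)(=O)c2cnc(O)nc2O)cc1`) gives 11700 nM and compound 2 (`CCCCOc1ccc(C(=O)NNC(=O)c2ccc(NS(=O)(=O)c3cnc(O)nc3O)cc2)cc1`) gives 9010 nM, so these two values lie within the usual scatter of each other. Compound 3 (`O=C(NNC(=O)c1cccc(Cl)c1)c1ccc(NS(=O)(=O)c2cnc(O)nc2O)cc1`) keeps the shared core but has 3-chlorophenyl in place of 4-butoxyphenyl on a carbonyl carbon. Going by the values given here, no measured pair of compounds shows this kind of swap on its own, so the guide is thin. In this assay the expected step of a 1.1-fold higher number from compound 2 to compound 3 (0.05 log units; within the scatter) stays within the scatter, with no clear direction. For compound 3 the estimated value is 10000 nM, with an expected range of 4000 nM to 25000 nM.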

Compound 3, half-maximal inhibitory concentration: 2290 nM
For compound 3 the middle estimate is 4.4-fold (0.64 log units) above the measured one; the whole stated range lies above it.
By their numbers in this assay, from the lowest: compound 3; then compounds 2 and 1 (each within the scatter of the next).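

In this assay the group on this carbonyl carbon clearly matters: 3-chlorophenyl in place of 4-butoxyphenyl gives a 3.9-fold lower number from compound 2 to compound 3 (0.59 log units; beyond the scatter) at this position. Putting (3-chlorophenyl)carbonyl in place of 2-fluorophenyl on an amine nitrogen gives a 5.1-fold lower number from compound 1 to compound 3 (0.71 log units; beyond the scatter) as well. The two earlier values, within the scatter of each other, gave no hint of such a shift.

As far as these compounds go, whether the gain belongs to the chlorine itself stays open, as does what a plain phenyl or a phenyl carrying a carboxylic acid would give here. Nothing available explains why the number falls.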